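The compounds below may be only part of what the source reports. "The series", "measured", "known", "first", "only" and "open" are said of these compounds alone.

Series notes, read in a functional assay on Huh-7 cells (Homo sapiens) for cytotoxicity, read by MTT assay, with a stated time of 3 days; a higher number here means that more compound is tolerated, a lower number that less compound is tolerated. Compound 1 `OC[C@H]1O[C@@H](n2cnc3c(COc4ccccc4)ncnc32)[C@H](O)[C@@H]1O` gives > 100000 nM, which is a limit of the assay and not a number. Going by the values given here, compound 2 `CN(Cc1ccccc1)Cc1ncnc2c1ncn2[C@@H]1O[C@H](CO)[C@@H](O)[C@H]1O` gives 9000 nM, the only actual number so far, so it stands as the sole quantified point.

Compound 3 `O=C(O)CNCc1ncnc2c1ncn2[C@@H]1O[C@H](CO)[C@@H](O)[C@H]1O` is still unmeasured. It carries (carboxymethyl)amino in place of benzyl(methyl)amino on a saturated chain carbon bound to an aromatic carbon. The six-membered aromatic ring of carbon only leaves with the benzyl(methyl)amino group, and the new group has no ring.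

Among the compounds with values here, one measured step bears on this change, at the same place: an at least 11-fold lower number from compound 1 to compound 2 (1.04 log units; beyond the scatter). It is large, so changes here can move the number well beyond the scatter, although a single step is thin support. A step of similar size towards a higher number is therefore expected in this assay, and a reading reported only as a limit would not be surprising.

The expected step is a 6.7-fold higher number from compound 2 to compound 3 (0.82 log units; beyond the scatter). For compound 3 the estimate is 60000 nM, with an expected range of 15000 nM to 100000 nM.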

Compound 3, half-maximal cytotoxic concentration: > 100000 nM
Compound 3: a limit, no number; the forecaster's own chance of this, stated with the estimate: 60%; at least 1.6-fold (0.22 log units) between middle value and limit.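

In this assay the change from benzyl(methyl)amino to (carboxymethyl)amino gives an at least 11-fold higher number from compound 2 to compound 3 (1.04 log units; beyond the scatter), so this place on a saturated chain carbon bound to an aromatic carbon can move the number in both directions, and compound 2 remains the only one of the three with an actual number. From the compounds shown here alone, compound 3 gives > 100000 nM, which is a limit of the assay and not a number, so the true size of this step stays unknown. The step from compound 1 to compound 3 cannot be read, and phenoxy and (carboxymethyl)amino cannot be ranked against each other, because both compounds sit at the same limit: the limit of > 100000 nM in this assay, at which 2 of the 3 values shown sit.

Which part of benzyl(methyl)amino goes with the lower number remains open: a methylamino group or a benzylamino group would separate the contribution of the methyl from that of the benzyl. Going by these compounds, whether the carboxylic acid itself matters in compound 3 is also open, and a methyl ester or a longer chain ending in the acid, at this same place, would bear on that.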